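This account rests on a few compounds, and the source may have more. Where it says the series, first, only, none or still open, it means among the compounds named here.

Measured in an assay on CHO cells for displacement of a labelled ligand from 5-hydroxytryptamine receptor 1B (Homo sapiens); on this read-out higher numbers stand for weaker inhibition and lower numbers for stronger inhibition:
compound 1 `O[C@H]1Cc2ccccc2C1NC1CCN(CCCc2c[nH]c3ccc(-n4cnnc4)cc23)CC1` — 300 nM
compound 2 `c1ccc(C2CCCCN2C2CCN(CCCc3c[nH]c4ccc(-n5cnnc5)cc34)CC2)cc1` — 410 nM
compound 3 `OC[C@H](NC1CCN(CCCc2c[nH]c3ccc(-n4ccnc4)cc23)CC1)c1ccccc1` — 100 nM

On these three numbers compound 1 stands second highest. Compound 2 sits nearest to it, within the usual scatter, so no order between the two is claimed. Compound 3 gives the lowest number of the set, and its gap to compound 1 lies beyond the scatter. Compound 4 `C[C@H](NCC1CCN(CCCc2c[nH]c3ccc(-n4cnnc4)cc23)CC1)c1ccccc1` is not yet measured. It differs from compound 1 by ((1-phenylethyl)amino)methyl in place of (2-hydroxy-2,3-dihydro-1H-inden-1-yl)amino on a saturated ring carbon. Among the compounds with values here, no measured pair isolates this change, so the expectation rests on compound 1 alone. In this assay the expected step is a 1.3-fold higher number from compound 1 to compound 4 (0.12 log units; within the scatter), meaning nothing beyond the scatter, with a small drift toward a higher number judged the more likely side. For compound 4 the estimate in this assay is 400 nM, within 120 nM to 1300 nM.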

Compound 4, half-maximal inhibitory concentration: 58 nM
For compound 4 the middle estimate is 6.9-fold (0.84 log units) above the measured one, outside the stated range (below it).
By their numbers in this assay, from the lowest: compounds 4 and 3 (each within the scatter of the next); then compounds 1 and 2 (each within the scatter of the next).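

In this assay, the saturated ring carbon proves sensitive to the group it carries: ((1-phenylethyl)amino)methyl in place of (2-hydroxy-2,3-dihydro-1H-inden-1-yl)amino gives a 5.2-fold lower number from compound 1 to compound 4 (0.71 log units; beyond the scatter). The change loses the five-membered non-aromatic ring and the oxygen and also moves the amine one carbon further out, so the step belongs to the whole exchange and to no single part of it. No available evidence accounts for the step.

Which part carries the step remains open. Comparison with (1-phenylethyl)amino directly on that ring carbon, or with a longer chain such as ((1-phenylethyl)amino)ethyl, would help separate these parts.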